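From a vinyl to a propargyl group on the chain

The source may report more compounds than this note shows. Statements on the series, on what has been measured and on what is new or still open speak of the compounds shown alone.

Among the compounds with values here, only two compounds built on the same core have been measured so far. In a functional assay on NCI-H292 cells (Homo sapiens) for inhibition, read by MTT assay, with a stated time of 72 h (a higher number here means a weaker inhibitor, a lower number a stronger inhibitor), compound 1 (`CCCO[C@@H]1C=CC(=O)[C@@H](CO)O1`) gives 15600 nM and compound 2 (`C=CCO[C@@H]1C=CC(=O)[C@@H](CO)O1`) gives 10300 nM and so stands level with compound 1 within the usual scatter. Compound 3 (`C#CCCO[C@@H]1C=CC(=O)[C@@H](CO)O1`) carries propargyl in place of vinyl on a saturated chain carbon bound to an oxygen on a saturated carbon and has not yet been tested. Within the data shown here, one measured step bears on this change, the swap of ethyl for vinyl at the same place: a 1.5-fold lower number from compound 1 to compound 2 (0.18 log units; within the scatter) and it stayed within the scatter. Among the measured compounds shown here, no measured compound yet carries a triple bond, so this evidence is thin. The expected step is a 1.0-fold lower number from compound 2 to compound 3 (0.01 log units; within the scatter) and no shift beyond the scatter is expected in this assay. For compound 3 the estimated value is 10000 nM with an expected range from 4500 nM to 22000 nM.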

Compound 3, half-maximal inhibitory concentration: 12700 nM
Estimate against measurement, compound 3: 1.3-fold (0.10 log units) below; low and high end bracket the measured number.
By their numbers in this assay, from the lowest: compounds 2, 3 and 1 (each within the scatter of the next).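

Across the three chain endings, neither a double nor a triple bond moves the result beyond the scatter in this assay (a 1.2-fold higher number from compound 2 to compound 3 (0.09 log units; within the scatter); a 1.2-fold lower number from compound 1 to compound 3 (0.09 log units; within the scatter)). Replacing allyl with but-3-yn-1-yl changes both the chain length and the bond type, and even this double change leaves compound 3 level with compound 2, so this position has so far accepted every small hydrocarbon ending shown. Nothing available explains why these compounds stay level.

Going by these compounds, all three endings contain only carbon and hydrogen, so it remains open whether an amine, a carboxylic acid or a phenyl ring at the chain end would shift the number beyond the scatter. A much longer chain is equally untested by these compounds, which leaves the limits of this position unknown.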